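A few compounds are considered here, and "the series" means these few. Any claim that something is new, unique, unknown or untested is made for them only; others in the source may bear on it.

Three measured compounds share one core and differ only in the group on the five-membered ring. Compound 1 `O=C(O)c1ccccc1-c1ccc(CCc2ncc(Cc3ccc(Cl)cc3)[nH]2)cc1` gives 2290 nM in an in vitro functional assay on cells for agonist activity at Bombesin receptor subtype-3 (Homo sapiens), read by luminescence and calcium flux; on this read-out lower numbers stand for an effect already at smaller amounts and higher numbers for an effect only at larger amounts of compound; compound 2 `O=C(O)c1ccccc1-c1ccc(CCc2ncc(-c3ccccc3)[nH]2)cc1` gives 4950 nM; compound 3 `CC(C)(C)c1cnc(CCc2ccc(-c3ccccc3C(=O)O)cc2)[nH]1` gives 4330 nM. Compound 3 thus sits second highest of the three, within the scatter of compound 1 and compound 2 alike. Compound 4 `CCC(C)(CC)Cc1cnc(CCc2ccc(-c3ccccc3C(=O)O)cc2)[nH]1` carries 2-ethyl-2-methylbutyl in place of tert-butyl on an aromatic carbon. For the measured compounds named here, the steps that bear on this are a 1.9-fold higher number from compound 1 to compound 3 (0.28 log units; within the scatter) and a 1.1-fold lower number from compound 2 to compound 3 (0.06 log units; within the scatter), and both stayed within the scatter, so another swap at the same position is expected to move the number little. Compound 4 is therefore expected near 3500 nM, between 1200 nM and 10000 nM, a step of a 1.2-fold lower number from compound 3 to compound 4 (0.09 log units; within the scatter) that is not expected to exceed the scatter.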

Compound 4, half-maximal effective concentration: 76 nM
Beside the measured number, compound 4's estimate is 46-fold (1.66 log units) above it; measured number outside the range, below it.
By their numbers in this assay, from the lowest: compound 4; then compounds 1, 3 and 2 (each within the scatter of the next, the first and the last beyond it).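

This position is far less forgiving than the first three compounds suggested: 2-ethyl-2-methylbutyl in place of tert-butyl gives a 57-fold lower number from compound 3 to compound 4 (1.76 log units; beyond the scatter), and in place of phenyl it gives a 65-fold lower number from compound 2 to compound 4 (1.81 log units; beyond the scatter). Even against the 4-chlorobenzyl group the change gives a 30-fold lower number from compound 1 to compound 4 (1.48 log units; beyond the scatter), a step far larger than any among the earlier compounds. No measurement here explains this gain. How a straight hexyl chain or a cyclohexylmethyl group would read at this position stays open, so the compounds shown cannot separate the size of the group from its branching.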